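Octyl in Place of Phenyl on Compound 2

The source may report more compounds than this note shows. Statements on the series, on what has been measured and on what is new or still open speak of the compounds shown alone.

In a functional assay on SW1573 cells (Homo sapiens) for antiproliferative activity, read by sulforhodamine B assay, with a stated time of 48 h (on this read-out higher numbers stand for weaker inhibition of growth and lower numbers for stronger inhibition of growth), compound 2 (`COC(=O)C#CC(CCc1ccccc1)O/C=C/C(=O)OC`) gives 2600 nM. Going by the values given here, the only other measured compound, compound 1 (`CCCCCC(C#CC(=O)OC)O/C=C/C(=O)OC`), gives 1700 nM, and the two values lie within the scatter of each other. Compound 3 (`CCCCCCCCCCC(C#CC(=O)OC)O/C=C/C(=O)OC`) has not yet been measured. It differs from compound 2 as follows: octyl in place of phenyl on a saturated chain carbon, three bonds along the chain from an oxygen on an unsaturated carbon and a triple-bonded carbon. Among the compounds with values here, one measured step bears on this change, at the same place: a 1.5-fold higher number from compound 1 to compound 2 (0.18 log units; within the scatter), which put phenyl in place of propyl and stayed within the scatter. Within the data shown here, that is a single step, and no measured compound carries octyl there, so the range has to stay wide. On the strength of that step, no shift beyond the scatter is expected in this assay. The expected step is a 1.3-fold lower number from compound 2 to compound 3 (0.11 log units; within the scatter). For compound 3 the estimated value is 2000 nM, with an expected range from 800 nM to 5000 nM.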

Compound 3, concentration for 50% growth inhibition: 2000 nM
Compound 3: the middle estimate sits on the measured number at the digits printed, and the stated range covers the measured number.
By their numbers in this assay, from the lowest: compounds 1, 3 and 2 (each within the scatter of the next).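

In this assay the step with octyl in place of phenyl is a 1.3-fold lower number from compound 2 to compound 3 (0.11 log units; within the scatter) and stays within the scatter, so on this read-out an open chain of eight carbons takes the place of a six-membered aromatic ring of carbon only without moving the number beyond it. The step with pentyl in place of hydrogen is a 1.2-fold higher number from compound 1 to compound 3 (0.07 log units; within the scatter) and also stays within the scatter, which means that extending the chain of compound 1 to that of compound 3 gives no shift that can be told apart from repeat measurements. Until now this position had offered only the comparison of phenyl with propyl, whereas propyl, phenyl and octyl now all lie within the scatter of one another on the saturated chain carbon, and the change tolerates both a ring and a much longer open chain there.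

No supporting measurement bears on why these three compounds lie so close together. The compounds shown leave open whether an amine, a carboxylic acid or a chain longer than octyl at this place would take the number beyond the scatter in either direction.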